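This account rests on a few compounds, and the source may have more. Where it says the series, first, only, none or still open, it means among the compounds named here.

Compound 1 `CCN(CC)CCNC(=O)c1ccc(C(CC)(CC)c2ccc(OCCC(O)(CC)CC)c(C)c2)n1CC` carries a 2-(diethylamino)ethyl group on an amide-type nitrogen and in a functional assay on MCF7 cells (Homo sapiens) for antiproliferative activity, read by MTT assay, with a stated time of 48 h (a lower number here means a stronger inhibitor, a higher number a weaker inhibitor), gives 550 nM as its half-maximal inhibitory concentration. Compound 2 `CCn1c(C(=O)Nc2cccc(C(F)(F)F)c2)ccc1C(CC)(CC)c1ccc(OCCC(O)(CC)CC)c(C)c1` has a 3-(trifluoromethyl)phenyl group in that place and gives > 50000 nM as a limit of the assay, not a number. Compound 3 `CCOc1ccc(NC(=O)c2ccc(C(CC)(CC)c3ccc(OCCC(O)(CC)CC)c(C)c3)n2CC)cc1` has a 4-ethoxyphenyl group there and gives > 50000 nM as a limit too. Compound 3 therefore stands at the limit of > 50000 nM in this assay, at which 2 of the 3 values shown sit, and has no exact value to start from.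

Compound 4 `CCC(C)C(NC(=O)c1ccc(C(CC)(CC)c2ccc(OCCC(O)(CC)CC)c(C)c2)n1CC)C(=O)OC` has not yet been measured. The change is a group of 9 heavy atoms (7 carbon, 2 oxygen; no ring) in place of a group of 9 heavy atoms (8 carbon, 1 oxygen; one six-membered aromatic ring of carbon only), on an amide-type nitrogen and so the aromatic ring of compound 3 leaves. The measured steps that bear on this are an at least 90-fold higher number from compound 1 to compound 2 (1.95 log units; beyond the scatter) and an at least 90-fold higher number from compound 1 to compound 3 (1.95 log units; beyond the scatter) and both are large and beyond the scatter. Each of them puts an aromatic ring where compound 1 has none. Compound 4 has no such ring, but it also lacks the 2-(diethylamino)ethyl group of compound 1. In this assay a modest move toward a lower number is therefore expected, far smaller than an at least 90-fold higher number from compound 1 to compound 3 (1.95 log units; beyond the scatter) and with a real chance that the result stays a limit. The expected change is an at least 2.0-fold lower number from compound 3 to compound 4 (0.30 log units; that floor lies within the scatter) and this is only an estimate. For compound 4 the estimated value is 25000 nM with an expected range from 3000 nM to 80000 nM as the likely span.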

Compound 4, half-maximal inhibitory concentration: > 50000 nM
Compound 4: a limit, no number (the forecaster's own chance of this, stated with the estimate: 50%); at least 2.0-fold (0.30 log units) between middle value and limit.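

The new group shows that taking the aromatic ring out of the group on the amide-type nitrogen is not enough on its own to give a measurable value: compound 4 has no ring in that group, and in this assay compound 4 gives > 50000 nM, which is a limit and not a number. Putting this ring-free group in place of 2-(diethylamino)ethyl gives an at least 90-fold higher number from compound 1 to compound 4 (1.95 log units; beyond the scatter), so a group without an aromatic ring can also end at the limit, and compound 1 remains the only compound shown with a measured number. The steps that link compound 2, compound 3 and compound 4 join one limit to another and cannot be read, so these three groups cannot be ranked: the limit of > 50000 nM in this assay, at which 3 of the 4 values shown sit.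

Going by these compounds, what remains open is which part of the 2-(diethylamino)ethyl group matters, the amine nitrogen or the chain that carries it. A dimethylamino or morpholine group on the same chain, a longer chain to the diethylamino group, or a simple ethyl group with no amine at all would help to separate these two parts.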